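The compounds below may be only part of what the source reports. "The series", "measured", "known", "first", "only" and "open" are said of these compounds alone.

Working notes on the series. The shared core is held across compound 1 `COc1ccc(/C=C/C(=O)NS(=O)(=O)c2ccc(Br)cc2)cc1`, compound 2 `O=C(/C=C/c1ccc([N+](=O)[O-])cc1)NS(=O)(=O)c1ccccc1` and compound 3 `O=C(/C=C/c1ccc([N+](=O)[O-])cc1)NS(=O)(=O)c1ccc(F)cc1`. In a functional assay on B16-F10 cells (Mus musculus) for antiproliferative activity, read by ELISA and MTT assay, with a stated time of 48 h (on this read-out higher numbers stand for weaker inhibition and lower numbers for stronger inhibition), compound 1 gives 5.8 ug/mL, compound 2 gives 4.8 ug/mL and compound 3 gives 2.2 ug/mL. Going by the values given here, compound 3 stands lowest of the three: the step of a 2.2-fold lower number from compound 2 to compound 3 (0.34 log units; beyond the scatter) separates it from compound 2, and the values of compound 1 and compound 3 lie further apart, though those two differ in more than one place and no single step is drawn between them. Compound 4 `O=C(/C=C/c1ccc([N+](=O)[O-])cc1)NS(=O)(=O)c1ccc(Br)cc1` differs from compound 3 by bromo in place of fluoro on an aromatic carbon. Among the compounds with values here, the only measured step that bears on this position is a 2.2-fold lower number from compound 2 to compound 3 (0.34 log units; beyond the scatter), a modest change; no measured pair swaps one halogen for another with the rest held constant. The exchange is therefore expected to leave the number close to that of compound 3, within or barely beyond the scatter, in either direction. Compound 4 is estimated at 2.5 ug/mL, with a range from 1.2 ug/mL to 5 ug/mL. This corresponds to an expected step of a 1.1-fold higher number from compound 3 to compound 4 (0.06 log units; within the scatter).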

Compound 4, half-maximal inhibitory concentration: 13.9 ug/mL
Estimate against measurement, compound 4: 5.6-fold (0.75 log units) below; the measured number lies above the stated range.
By their numbers in this assay, from the lowest: compound 3; then compounds 2 and 1 (each within the scatter of the next); then compound 4.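

In this assay, the halogen at this position is not interchangeable: a 6.3-fold higher number from compound 3 to compound 4 (0.80 log units; beyond the scatter) shows that 4-fluorophenyl to 4-bromophenyl alone moves the number, and the two halogens fall on opposite sides of the unsubstituted compound 2, with a 2.2-fold lower number from compound 2 to compound 3 (0.34 log units; beyond the scatter) set against a 2.9-fold higher number from compound 2 to compound 4 (0.46 log units; beyond the scatter). With the bromo held, a 2.4-fold higher number from compound 1 to compound 4 (0.38 log units; beyond the scatter) shows that nitro in place of methoxy also moves the number, so that site responds too. Nothing at hand explains why bromo and fluoro read so differently here.

The compounds shown leave open where chloro would fall relative to fluoro and bromo, and how an amine at this position would read. From the compounds shown here alone, whether bromo in place of fluoro gives a step of similar size with methoxy in place of nitro also stays open.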